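This account rests on a few compounds, and the source may have more. Where it says the series, first, only, none or still open, it means among the compounds named here.

Compound 1 `CCN1CCN(c2cc(C)c3cc(NC(=O)c4cc(Cl)cc(Cl)c4)ccc3n2)CC1` gives the lowest number of the three measured in a functional assay on SK-BR-3 cells (Homo sapiens) for antiproliferative activity, read by MTT assay, with a stated time of 72 h (a lower number here means a stronger inhibitor, a higher number a weaker inhibitor), at 2660 nM. Compound 2 `CNc1cc(C)c2cc(NC(=O)c3ccc(Cl)c(Cl)c3)ccc2n1` gives 6350 nM, and compound 3 `Cc1cc(N2CCN(C)CC2)nc2ccc(NC(=O)c3ccc(Cl)c(Cl)c3)cc12` gives 6320 nM; each of these stands beyond the scatter above compound 1. Going by the values given here, the one single-point step measured so far, a 1.0-fold lower number from compound 2 to compound 3 (0.00 log units; within the scatter), concerns the amine on the shared core and not the aryl amide, so it does not bear on the change now in question. Compound 4 `CCN1CCN(c2cc(C)c3cc(NC(=O)c4ccccc4)ccc3n2)CC1` differs from compound 1 by phenyl in place of 3,5-dichlorophenyl on a carbonyl carbon. Among the compounds with values here, no measured pair isolates this exchange of 3,5-dichlorophenyl for phenyl on the carbonyl carbon, so the series offers no direct precedent. Lacking such a step, a weakening of moderate size is expected, and the estimate means a 2.4-fold higher number from compound 1 to compound 4 (0.39 log units; beyond the scatter). Compound 4 is therefore expected to give about 6500 nM in this assay, with a range of 2200 nM to 20000 nM.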

Compound 4, half-maximal inhibitory concentration: 18400 nM
Estimate against measurement, compound 4: 2.8-fold (0.45 log units) below; the range from low to high includes it.
By their numbers in this assay, from the lowest: compound 1; then compounds 3 and 2 (each within the scatter of the next); then compound 4.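

In this assay, the group on the carbonyl carbon proves to be a point of sensitivity: phenyl in place of 3,5-dichlorophenyl gives a 6.9-fold higher number from compound 1 to compound 4 (0.84 log units; beyond the scatter). Going by these compounds alone, this is the first step that lies beyond the scatter, whereas the exchange of amine on the shared core gave a 1.0-fold lower number from compound 2 to compound 3 (0.00 log units; within the scatter). Nothing available explains why the two chlorine atoms matter here.

The step removes both chlorine atoms at once, so the share of each remains unresolved, and a phenyl carrying a single chlorine would separate them. On these data alone, it also remains open whether fluorine, methyl or methoxy on the same ring could stand in for chlorine, or whether this sensitivity is specific to chlorine.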